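The compounds below may be only part of what the source reports. "The series", "measured", "known", "first", "only" and "open" are said of these compounds alone.

In an ADME assay on the whole organism (plasma) for pharmacokinetics, with Rattus norvegicus as the target, at a dose of 5 mg/kg by the oral route (on this read-out higher numbers stand for higher exposure at the dose given and lower numbers for lower exposure), two compounds built on a shared core have been measured so far. Compound 1 `CC[C@H](C)[C@@H]1C(=O)N[C@H](C2Cc3ccccc3C2)C(=O)N1[C@@H](C(=O)N1CCOCC1)c1cnc(C)cc1C` gives 1110 ng.h/mL. Compound 2 `CC[C@H](C)[C@@H]1C(=O)N[C@H](C2Cc3ccccc3C2)C(=O)N1[C@@H](C(=O)N(C)C)c1ccc(C)nc1C` gives 4730 ng.h/mL, the higher of the two numbers, and the gap between compound 1 and compound 2 lies beyond the usual scatter of repeated measurements. Compound 3 `CC[C@H](C)[C@@H]1C(=O)N[C@H](C2Cc3ccccc3C2)C(=O)N1[C@@H](C(=O)N(C)C)c1ccc(C)[n+]([O-])c1` has not yet been measured in this assay. It differs from compound 2 in one place: a group of 8 heavy atoms (6 carbon, 1 nitrogen, 1 oxygen; one six-membered aromatic ring with 1 hetero atom) in place of a group of 8 heavy atoms (7 carbon, 1 nitrogen; one six-membered aromatic ring with 1 hetero atom), on a saturated chain carbon bound to an amide-type nitrogen in a ring and a carbonyl carbon. Within the data shown here, no pair of measured compounds shows a step of this kind, so the two measured values alone give no guide to its direction or size. The expected step in this assay is a 3.2-fold lower number from compound 2 to compound 3 (0.50 log units; beyond the scatter), a downward move that may reach beyond the scatter. Compound 3 is therefore estimated at 1500 ng.h/mL, within a range from 400 ng.h/mL to 5000 ng.h/mL.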

Compound 3, area under the concentration-time curve: 24 ng.h/mL
For compound 3 the middle estimate is 63-fold (1.80 log units) above the measured one; the measured number lies below the stated range.
By their numbers in this assay, from the lowest: compound 3; then compound 1; then compound 2.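

In this assay, the exchange of the 2,6-dimethylpyridin-3-yl group on the saturated chain carbon bound to an amide-type nitrogen in a ring and a carbonyl carbon gives a 200-fold lower number from compound 2 to compound 3 (2.29 log units; beyond the scatter). Among these compounds, this is the first single-place step seen here, and it shows that this position can carry a very large change in the read-out, even though the leaving and entering groups match in heavy-atom count, hydrogen-bond donors and acceptors, and net charge. No measurement shown here accounts for the size of the step. The compounds shown leave open how much of the step goes with the entering oxygen and how much with the change from seven carbons to six. They also leave open how a phenyl ring or a methoxy-bearing pyridine ring would read at this place.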